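A few compounds are considered here, and "the series" means these few. Any claim that something is new, unique, unknown or untested is made for them only; others in the source may bear on it.

The series shares one core. Compound 1 is `CN(C)CCCn1cnnc1-c1cc(Oc2ccc(NC(=O)Nc3ccc(Cl)c(C(F)(F)F)c3)cc2F)ccn1` and compound 2 is `CN(C)CCCn1cnnc1-c1cc(Oc2ccc(NC(=O)Nc3ccccc3C(F)(F)F)cc2F)ccn1`. Within the data shown here, in a functional assay on HT-29 cells (Homo sapiens) for antiproliferative activity, read by MTT assay, with a stated time of 72 h (on this read-out higher numbers stand for weaker inhibition and lower numbers for stronger inhibition), compound 1 gives 1400 nM, and in this assay compound 2 gives 3130 nM, the higher of the two numbers so far, set apart from compound 1 by a 2.2-fold higher number from compound 1 to compound 2 (0.35 log units; beyond the scatter). Compound 3 is `CN(C)CCCn1cnnc1-c1cc(Oc2ccc(NC(=O)Nc3ccc(F)c(F)c3)cc2F)ccn1`; it differs from compound 2 by 3,4-difluorophenyl in place of 2-(trifluoromethyl)phenyl on an amide-type nitrogen. Among the measured compounds shown here, the only measured step touching this nitrogen is a 2.2-fold higher number from compound 1 to compound 2 (0.35 log units; beyond the scatter), which exchanged the whole aryl group, so no direct read exists for a 3,4-difluorophenyl at this place. The expectation can rest only on that one modest step, and it suggests a move no further than the scatter, with a slight lean back toward the number of compound 1. Compound 3 is therefore expected to give about 2200 nM in this assay, estimated within 800 nM to 6000 nM, which means an expected step of a 1.4-fold lower number from compound 2 to compound 3 (0.15 log units; within the scatter).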

Compound 3, half-maximal inhibitory concentration: 1210 nM
Compound 3: the middle estimate sits 1.8-fold (0.26 log units) above what was measured; the range from low to high includes it.
By their numbers in this assay, from the lowest: compounds 3 and 1 (each within the scatter of the next); then compound 2.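

At the aryl group on the amide-type nitrogen, the series now has a second exchange that moves the number beyond the scatter (a 2.6-fold lower number from compound 2 to compound 3 (0.41 log units; beyond the scatter)) in this assay, while the exchange between the two other aryl groups stays within it (a 1.2-fold lower number from compound 1 to compound 3 (0.06 log units; within the scatter)). Among these three groups, 2-(trifluoromethyl)phenyl alone stands apart; 3,4-difluorophenyl and 4-chloro-3-(trifluoromethyl)phenyl cannot be told apart, and the latter shows that carrying a trifluoromethyl group does not by itself set a compound apart. No measured evidence accounts for these differences.

From the compounds shown here alone, what separates 2-(trifluoromethyl)phenyl from the other two groups remains open. An unsubstituted phenyl, a 3-(trifluoromethyl)phenyl or a pyridine ring on this nitrogen could show whether the numbers stay with compound 1 and compound 3 or go with compound 2.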